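The compounds below may be only part of what the source reports. "The series", "measured", "known", "first", "only" and "open" are said of these compounds alone.

Measured so far, in a functional assay on BGC-823 cells (Homo sapiens) for cytotoxicity, read by MTT assay; on this read-out higher numbers stand for weaker inhibition and lower numbers for stronger inhibition:

Compound 1 `Cc1ccccc1Nc1nc(C)c(C(=O)/C=C/c2ccc(Cl)cc2)s1` gives > 25000 nM, which is a limit of the assay and not a number.
Compound 2 `Cc1ccc(Nc2nc(C)c(C(=O)/C=C/c3ccc(Cl)cc3)s2)cc1` gives > 25000 nM, again a limit rather than a number.
Compound 3 `Cc1ccc(Nc2nc(C)c(C(=O)/C=C/c3ccccc3Cl)s2)cc1` gives > 25000 nM, also a limit and not a number.

Among the measured compounds shown here, all three values therefore sit at the limit of > 25000 nM in this assay, at which 3 of the 3 values shown sit, and no step among the measured compounds can be read. From compound 2 to compound 1 the change is 2-methylphenyl in place of 4-methylphenyl on a nitrogen on an aromatic ring; in this assay the step is a step that the two limits leave unreadable from compound 2 to compound 1 because every value rests at the limit of > 25000 nM in this assay, at which 3 of the 3 values shown sit. From compound 2 to compound 3 the step is a step that the two limits leave unreadable from compound 2 to compound 3, for the same reason.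

Compound 4 `Cc1ccccc1Nc1nc(C)c(C(=O)/C=C/c2ccccc2Cl)s1` has not been measured. From compound 3 to compound 4 the change is 2-methylphenyl in place of 4-methylphenyl on a nitrogen on an aromatic ring, the same change as from compound 2 to compound 1, made at the same place. The two cores differ by 2-chlorophenyl in place of 4-chlorophenyl on a double-bonded chain carbon bound to a double-bonded chain carbon.

Since every measured value is a limit, the expectation for compound 4 rests only on compound 3 sitting at the limit of > 25000 nM in this assay, at which 3 of the 3 values shown sit. The step from compound 3 to compound 4 is expected to be a step that the limit leaves unreadable from compound 3 to compound 4. Compound 4 is estimated at 40000 nM in this assay. The estimate for compound 4 is expected to lie between 15000 nM and 150000 nM, most likely reported as a limit once more.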

Compound 4, half-maximal inhibitory concentration: > 25000 nM
Compound 4 gave a limit, no number (the forecaster's own chance of this, stated with the estimate: 85%); the middle value lies beyond the limit too.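

In this assay compound 4 gives > 25000 nM, a limit and not a number. No step to compound 4 from compound 3 or compound 1 can be read: the limit of > 25000 nM in this assay, at which 4 of the 4 values shown sit.

The compounds shown leave open whether 2-methylphenyl against 4-methylphenyl, or 2-chlorophenyl against 4-chlorophenyl, makes any difference in this assay.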